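Swapping a nitrophenyl amide for a cyclohexyl amide

The source may hold more compounds than are shown below. What is called first, only, known or untested is meant among the compounds shown, and "the series" means these compounds.

Compound 1 `O=C(Nc1cc(-c2ccccc2)nn1-c1ccccc1)c1cccc([N+](=O)[O-])c1` carries a 3-nitrophenyl group on the carbonyl carbon of its amide. In an assay on HEK293 cells for displacement of a labelled ligand from metabotropic glutamate receptor 5 (Rattus norvegicus) (on this read-out lower numbers stand for stronger inhibition and higher numbers for weaker inhibition), compound 1 gives 2220 nM. Within the data shown here, it is the only compound here with a number: compound 2 `O=C(Nc1cc(-c2ccccc2)nn1-c1ccccc1)c1cc([N+](=O)[O-])cc([N+](=O)[O-])c1`, with two nitro groups on the same ring, shows in this assay only "not determined" (no result reported). Compound 3 `O=C(Nc1cc(-c2ccccc2)nn1-c1ccccc1)C1CCCCC1` has not yet been tested. Among the measured compounds shown here, it differs from compound 1 in one place (cyclohexyl in place of 3-nitrophenyl on a carbonyl carbon), and no pair of measured compounds shows what such a change does. With a single number available, the expectation rests on compound 1 alone. Exchanging the aromatic ring for a non-aromatic ring of carbon only is expected to weaken binding moderately, so the step is estimated as a 2.3-fold higher number from compound 1 to compound 3 (0.35 log units; beyond the scatter). Compound 3 is thus expected to give about 5000 nM in this assay, within a range of 1500 nM to 20000 nM, with some chance that only a limit is reported.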

Compound 3, inhibition constant: 10100 nM
Compound 3: middle estimate off by 2.0-fold (0.31 log units), on the low side; low and high end bracket the measured number.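

In this assay, among these compounds, the change gives a 4.5-fold higher number from compound 1 to compound 3 (0.66 log units; beyond the scatter), which is the first measured sign that the group on this carbonyl carbon affects the read-out, with cyclohexyl giving weaker inhibition than 3-nitrophenyl. This single step swaps more than one feature at once: the aromatic ring gives way to a non-aromatic one, and the nitrogen and oxygen atoms of the nitro group disappear. No measurement at hand explains the weaker inhibition.

From the compounds shown here alone, it therefore remains open how much of the step belongs to the loss of the nitro group and how much to the loss of the aromatic ring, a question that plain phenyl on the same carbonyl carbon could help to separate. The compounds shown also leave open how a pyridine ring or a small methyl group would fare at this place.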